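The source may hold more compounds than are shown below. What is called first, only, known or untested is meant among the compounds shown, and "the series" means these compounds.

In a functional assay (QGY7701 cells, Homo sapiens) for inhibition, read by MTT assay, with a stated time of 48 h (a higher number here means a weaker inhibitor, a lower number a stronger inhibitor), three amides on the shared core have been measured. Compound 1 (`COc1ccc2c(=O)c(/C=C/C(=O)Nc3cccc(Cl)c3)coc2c1`) gives > 100000 nM, which is a limit of the assay and not a number. Compound 2 (`COc1ccc2c(=O)c(/C=C/C(=O)NCc3cccc(F)c3)coc2c1`) gives 28600 nM. Compound 3 (`COc1ccc2c(=O)c(/C=C/C(=O)NCc3ccc(F)cc3)coc2c1`) gives 7960 nM, the lowest reading so far in the series.

Compound 4 (`COc1ccc(NC(=O)/C=C/c2coc3cc(OC)ccc3c2=O)cc1`) is reached from compound 3 by 4-methoxyphenyl in place of 4-fluorobenzyl on an amide-type nitrogen, with 4-methoxyphenyl in place of 4-fluorobenzyl on an amide-type nitrogen. Like compound 1, it carries a substituted phenyl rather than a benzyl on that nitrogen.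

The most relevant evidence is the pair of steps from the phenyl amide to the benzyl amides: an at least 12-fold lower number from compound 1 to compound 3 (1.09 log units; beyond the scatter) and an at least 3.4-fold lower number from compound 1 to compound 2 (0.54 log units; beyond the scatter). Both are bounded only, as the limit of > 100000 nM in this assay, at which 1 of the 3 values shown sits, applies to compound 1. The fluorine shift within the benzyl pair, a 3.6-fold lower number from compound 2 to compound 3 (0.56 log units; beyond the scatter), shows that the ring substituent also moves the number, so the 4-methoxy group adds uncertainty. Among the compounds with values here, compound 1 is the only phenyl example, and its substituent differs.

A modest to large rise beyond the scatter is therefore expected in this assay, reversing part of the gain seen in an at least 12-fold lower number from compound 1 to compound 3 (1.09 log units; beyond the scatter). The expected change is a 5.7-fold higher number from compound 3 to compound 4 (0.75 log units; beyond the scatter). The estimated value for compound 4 is 45000 nM, with an expected range of 15000 nM to 100000 nM.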

Compound 4, half-maximal inhibitory concentration: > 100000 nM
Compound 4 ended at the assay's limit; the forecaster's own chance of this, stated with the estimate: 40%; at least 2.2-fold (0.34 log units) between middle value and limit.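

In this assay compound 4 gives > 100000 nM, which is a limit of the assay and not a number. Replacing 4-fluorobenzyl with 4-methoxyphenyl on the amide-type nitrogen gives an at least 12-fold higher number from compound 3 to compound 4 (1.09 log units; beyond the scatter), and the same kind of change from the other benzyl amide gives an at least 3.4-fold higher number from compound 2 to compound 4 (0.54 log units; beyond the scatter), so the earlier result for a phenyl on this nitrogen is no longer confined to the 3-chlorophenyl of compound 1. Among the four compounds, the two phenyl amides, compound 1 and compound 4, both stand at the limit, while the two benzyl amides, compound 2 and compound 3, give numbers, with no compound against this pattern, but the step between compound 1 and compound 4 cannot be read, and any ranking of 3-chlorophenyl against 4-methoxyphenyl is unavailable because of the shared ceiling: the limit of > 100000 nM in this assay, at which 2 of the 4 values shown sit.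

Compound 3 and compound 4 differ in both the chain carbon and the ring substituent, so the share of each in the step remains unresolved. A 4-methoxybenzyl on this nitrogen would separate the two, and a 2-phenylethyl would show whether a longer chain extends the trend from phenyl to benzyl.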